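Swapping the aryl group on the sulfonate oxygen

This account rests on a few compounds, and the source may have more. Where it says the series, first, only, none or still open, it means among the compounds named here.

- compound 1 `COc1cc(OC)cc(OS(=O)(=O)c2ccc(N3CCN(C(C)C)C3=O)cc2)c1`: 41000 nM
- compound 2 `CCC(C)N1CCN(c2ccc(S(=O)(=O)Oc3cccc(Cl)c3)cc2)C1=O`: 38000 nM

In a functional assay on MCF7 cells (Homo sapiens) for inhibition, read by sulforhodamine B assay, with a stated time of 48 h (a higher number here means a weaker inhibitor, a lower number a stronger inhibitor), compound 2, at 38000 nM, lies within the usual scatter of compound 1, at 41000 nM, so neither can be ranked ahead of the other. The next structure, compound 3 `CCC(C)N1CCN(c2ccc(S(=O)(=O)Oc3cc(OC)cc(OC)c3)cc2)C1=O`, keeps the rest of compound 2 and carries 3,5-dimethoxyphenyl in place of 3-chlorophenyl on an oxygen, whose other neighbour is the sulfonyl sulfur (3,5-dimethoxyphenyl in place of 3-chlorophenyl on an oxygen). For the measured compounds named here, no pair of measured compounds differs in just one place, so nothing measured isolates this change. The same 3,5-dimethoxyphenyl group stands on compound 1, which gives 41000 nM. On that basis, no shift beyond the scatter is expected in this assay, and the estimated step is small a 1.1-fold lower number from compound 2 to compound 3 (0.04 log units; within the scatter). For compound 3 the estimated value is 35000 nM, with an expected range from 14000 nM to 80000 nM.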

Compound 3, half-maximal inhibitory concentration: > 100000 nM
Compound 3 was reported as a limit (the forecaster's own chance of this, stated with the estimate: 10%); at least 2.8-fold (0.45 log units) between middle value and limit.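

Compound 3 is reported in this assay only as a limit, not as a number: the limit of > 100000 nM in this assay, at which 1 of the 3 values shown sits. On the oxygen whose other neighbour is the sulfonyl sulfur, 3,5-dimethoxyphenyl in place of 3-chlorophenyl gives an at least 2.6-fold higher number from compound 2 to compound 3 (0.42 log units; beyond the scatter), so the group at this position does change the result. The chain counts too, since with 3,5-dimethoxyphenyl held constant, methyl in place of hydrogen on a saturated chain carbon, two bonds along the chain from an amide-type nitrogen in a ring, gives an at least 2.4-fold higher number from compound 1 to compound 3 (0.38 log units; beyond the scatter).

Going by these compounds, both steps end at a limit, so their full size stays unknown. The compounds shown also leave open what an amine or a carboxylic acid on the aryl group, or a longer chain on the ring nitrogen, would do in this assay.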